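A Smaller Ring on a Side Chain

The source may report more compounds than this note shows. Statements on the series, on what has been measured and on what is new or still open speak of the compounds shown alone.

- Compound 1 `Cc1ccc(-c2nc3cc(NC(=O)CN4CCN(C)CC4)ccc3[nH]2)cc1` gives > 50000 nM (a limit, not a number)
- Compound 2 `Cn1cccc1-c1nc2cc(NC(=O)CCl)ccc2[nH]1` gives 1800 nM
- Compound 3 `O=C(CCCl)Nc1ccc2[nH]c(-c3ccc(Br)cc3)nc2c1` gives 11300 nM

All three compounds were tested in a functional assay on HepG2 cells (Homo sapiens) for cytotoxicity, read by MTT assay, with a stated time of 72 h; on this read-out lower numbers stand for stronger inhibition and higher numbers for weaker inhibition. Compound 1 has no exact value and sits at the limit of > 50000 nM in this assay, at which 1 of the 3 values shown sits. For the measured compounds named here, the assay therefore shows only that compound 1 lies at this limit, not how far past it the true value falls. Going by the values given here, compound 2 and compound 3 have measured numbers, but no pair of tested compounds differs in just one place, so none of them gives a direct measure of a single change.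

The next compound, compound 4 `Cc1ccc(-c2nc3cc(NC(=O)CN4CCCC4)ccc3[nH]2)cc1`, keeps the core of compound 1. It carries pyrrolidin-1-yl in place of 4-methylpiperazin-1-yl on a saturated chain carbon bound to a carbonyl carbon. Among the compounds with values here, no measured step shows what this swap does, so no change beyond the usual scatter is expected, and compound 4 may well reach the limit too. This expectation rests on compound 1, whose reading is the limit > 50000 nM. The estimated change is an at least 1.1-fold lower number from compound 1 to compound 4 (0.04 log units; that floor lies within the scatter), which is small and carries no clear direction. For compound 4 the estimated value is 45000 nM, with an expected range from 15000 nM to 100000 nM.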

Compound 4, half-maximal inhibitory concentration: > 50000 nM
Compound 4: no number, only a limit; the forecaster's own chance of this, stated with the estimate: 50%; middle value at least 1.1-fold (0.04 log units) from the limit.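

In this assay compound 4 gives > 50000 nM, which is a limit and not a number. Compound 1 also rests on a limit, so the swap of 4-methylpiperazin-1-yl for pyrrolidin-1-yl between compound 1 and compound 4 gives no step that can be read: the limit of > 50000 nM in this assay, at which 2 of the 4 values shown sit.

The compounds shown leave open how far past this limit the true values of compound 1 and compound 4 lie, and whether the swap changes anything at all.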